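The compounds below may be only part of what the source reports. "The series", "measured", "known", "first", "only" and "open" are said of these compounds alone.

Measured so far in an assay on isolated protein for inhibition of Nicotinamide phosphoribosyltransferase (Homo sapiens), read by WST assay, with stated times of 60 min, 5 min and 30 min, in the presence of a further agent that is not named here; a higher number here means a weaker inhibitor, a lower number a stronger inhibitor:

Compound 1, `O=C(/C=C/c1cccnc1)NCCCCCCCc1ccc(S(=O)(=O)Nc2ccccc2)cc1`, gives 16.4 nM.
Compound 2, `O=C(/C=C/c1cccnc1)NCCCc1cccc(S(=O)(=O)Nc2ccccc2)c1`, gives 235 nM.
Compound 3, `Cc1ccc(C)c(NS(=O)(=O)c2cccc(CCCCCCNC(=O)/C=C/c3cccnc3)c2)c1`, gives 11.6 nM.

Compound 3 has the lowest number of the three. Its gap to compound 1 lies within the usual scatter, so the two cannot be placed in order; compound 2 stands well beyond that scatter, with the clearly higher number.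

Compound 4, `O=C(/C=C/c1cccnc1)NCCCCCCc1cccc(S(=O)(=O)Nc2ccc(C(F)(F)F)cc2)c1`, differs from compound 3 in one place: 4-(trifluoromethyl)phenyl in place of 2,5-dimethylphenyl on a sulfonamide nitrogen. Going by the values given here, no measured pair shows this kind of change, so there is no step to lean on. The expectation is a step from compound 3 to compound 4 of a 1.7-fold higher number from compound 3 to compound 4 (0.24 log units; within the scatter) in this assay, small and not beyond the scatter, perhaps slightly toward a higher number. Compound 4 is therefore estimated at 20 nM, with a range from 6 nM to 70 nM.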

Compound 4, half-maximal inhibitory concentration: 24.5 nM
For compound 4 the middle estimate is 1.2-fold (0.09 log units) below the measured one; low and high end bracket the measured number.
By their numbers in this assay, from the lowest: compounds 3, 1 and 4 (each within the scatter of the next, the first and the last beyond it); then compound 2.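

In this assay, going by these compounds alone, 4-(trifluoromethyl)phenyl in place of 2,5-dimethylphenyl on a sulfonamide nitrogen gives a 2.1-fold higher number from compound 3 to compound 4 (0.32 log units; beyond the scatter), the first step here that isolates a single change. This position therefore accepts one substituted phenyl in exchange for another at the cost of only a modest loss of inhibition. Nothing available explains the size of this step.

Going by these compounds, how a cyclohexyl group in that place would fare remains open, as does the effect of an amine or a carboxylic acid on the phenyl.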